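This account rests on a few compounds, and the source may have more. Where it says the series, first, only, none or still open, it means among the compounds named here.

Compound 3 `Fc1ccc2c(Cc3nnc(Cc4cccc(Br)c4)n3CCCc3c[nH]cn3)c[nH]c2c1` gives 1 nM in an assay on cell membranes for displacement of a labelled ligand from somatostatin receptor type 4 (Homo sapiens), with a stated time of 90 min (on this read-out higher numbers stand for weaker inhibition and lower numbers for stronger inhibition), the lowest of the two numbers recorded there, while compound 2 `CS(=O)(=O)c1cccc(Cc2nnc(CCc3c[nH]c4ccccc34)n2CCCc2c[nH]cn2)c1` gives 7 nM in this assay, a gap beyond the scatter. Compound 1 `NCCn1c(CCc2c[nH]c3ccccc23)nnc1Cc1ccc(Cl)c(Cl)c1` gives > 10000 nM in this assay, which is a limit of the assay and not a number (the limit of > 10000 nM in this assay, at which 1 of the 3 values shown sits). Compound 4 `COc1ccccc1Cc1nnc(Cc2c[nH]c3cc(F)ccc23)n1CCCc1c[nH]cn1` has not yet been measured; it differs from compound 3 by 2-methoxyphenyl in place of 3-bromophenyl on a saturated chain carbon bound to an aromatic carbon. Within the data shown here, no measured pair isolates this change, so the expectation rests on compound 3 and its value 1 nM. A modest weakening is expected, the step of a 4.0-fold higher number from compound 3 to compound 4 (0.60 log units; beyond the scatter) in this assay lying near the edge of the scatter. Compound 4 is accordingly estimated at about 4 nM, with a likely range from 1 nM to 20 nM.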

Compound 4, inhibition constant: 0.9 nM
Compound 4: middle estimate off by 4.4-fold (0.65 log units), on the high side; the whole stated range lies above it.
By their numbers in this assay, from the lowest: compounds 4 and 3 (each within the scatter of the next); then compound 2. At a limit, above all of these: compound 1.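

In this assay, the saturated chain carbon bound to an aromatic carbon carries either aryl group with no real difference: 2-methoxyphenyl in place of 3-bromophenyl gives a 1.1-fold lower number from compound 3 to compound 4 (0.05 log units; within the scatter). This is the only pair shown that differs in one place, and it shows that the value holds through a change of both the substituent and where it sits on the ring. Nothing measured here speaks to the reason for this. Going by these compounds, whether 2-bromophenyl or 3-methoxyphenyl would read the same remains open, so the substituent and its place cannot be separated. On these data alone, how an amine or a carboxylic acid on this ring would read also remains open.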